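A few compounds are considered here, and "the series" means these few. Any claim that something is new, unique, unknown or untested is made for them only; others in the source may bear on it.

Measured so far in a functional assay on M21 cells (Homo sapiens) for antiproliferative activity, read by sulforhodamine B assay, with a stated time of 48 h; a higher number here means a weaker inhibitor, a lower number a stronger inhibitor:
compound 1 `CCC(=O)Nc1cccc(S(=O)(=O)Oc2ccccc2C(C)C)c1` — 25000 nM
compound 2 `CCCC(=O)Nc1cccc(S(=O)(=O)Oc2ccccc2C(C)C)c1` — 20000 nM

Compound 1 stands at the highest of the two numbers shown, and the only other measured compound lies close by: the step of a 1.3-fold lower number from compound 1 to compound 2 (0.10 log units; within the scatter) is within the scatter, so the two cannot be ordered against each other.

Compound 3 `CC(C)c1ccccc1OS(=O)(=O)c1cccc(NC(=O)CCCl)c1` differs from compound 1 by chloro in place of hydrogen on a saturated chain carbon, two bonds along the chain from a carbonyl carbon. For the measured compounds named here, the single measured step at this place is a 1.3-fold lower number from compound 1 to compound 2 (0.10 log units; within the scatter), a methyl entering where compound 3 takes a chloro; no chloro substitution has been measured anywhere. On that one step, the expectation is a change of a 1.3-fold lower number from compound 1 to compound 3 (0.10 log units; within the scatter), that is, nothing beyond the scatter, with a wide range to allow for the unmeasured group.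

For compound 3 the estimated value in this assay is 20000 nM, with a range from 7000 nM to 50000 nM.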

Compound 3, half-maximal inhibitory concentration: > 40000 nM
Compound 3 gave a limit, no number; the forecaster's own chance of this, stated with the estimate: 15%; middle value at least 2.0-fold (0.30 log units) away from the limit.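

Compound 3 gives > 40000 nM in this assay, and this is a limit of the assay, not a number. The steps read an at least 1.6-fold higher number from compound 1 to compound 3 (0.20 log units; that floor lies within the scatter) and an at least 2.0-fold higher number from compound 2 to compound 3 (0.30 log units; that floor lies within the scatter); both floors lie within the scatter, so neither step alone establishes a real loss of activity. For the compounds shown here, what is new is a first reading for chloro on a saturated chain carbon, two bonds along the chain from a carbonyl carbon: this change brings no lower number, and its direction, so far as the floors go, runs opposite to the methyl step, which itself stayed within the scatter.

As far as these compounds go, how far the true value of compound 3 lies past its limit stays open: the limit of > 40000 nM in this assay, at which 1 of the 3 values shown sits. Also open, from the compounds shown here alone, is whether a fluoro, a hydroxyl or an amine on the same carbon would move the number clear of the scatter around compound 1.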